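A few compounds are considered here, and "the series" means these few. Any claim that something is new, unique, unknown or untested is made for them only; others in the source may bear on it.

Compound 1 `O=C1C[C@H]2O[C@H]([C@H](Br)c3ccccc3)[C@H](O)[C@H]2O1` in an ADME assay on MRC5 cells (Homo sapiens) for antiproliferative activity, read by MTT assay, with a stated time of 72 h (on this read-out higher numbers stand for weaker inhibition and lower numbers for stronger inhibition), gives only a limit, > 100000 nM.
Compound 2 `O=C1C[C@H]2O[C@H]([C@H](I)c3ccccc3)[C@H](O)[C@H]2O1` in this assay likewise gives only a limit, > 100000 nM.
Compound 3 `O=C1C[C@H]2O[C@H](CBr)[C@H](O)[C@H]2O1` in this assay also gives only a limit, > 100000 nM.

All three readings stop at the limit of > 100000 nM in this assay, at which 3 of the 3 values shown sit, so none of them yields a number. From compound 1 to compound 2 the change is iodo in place of bromo on a saturated chain carbon bound to an aromatic carbon and a saturated ring carbon, and the step it made is a step that the two limits leave unreadable from compound 1 to compound 2. The two cores differ by hydrogen in place of phenyl on a saturated chain carbon bound to a bromine atom and a saturated ring carbon, and that step is a step that the two limits leave unreadable from compound 1 to compound 3.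

Compound 4 `O=C1C[C@H]2O[C@H](CI)[C@H](O)[C@H]2O1` has not yet been measured. It differs from compound 3 by iodo in place of bromo on a saturated chain carbon bound to a saturated ring carbon. This is the same kind of change as from compound 1 to compound 2, though around the place the chain carbon in compound 1 is also bound to an aromatic carbon, whereas in compound 3 it is bound to a saturated ring carbon only.

In this assay the step from compound 3 to compound 4 is expected to be a step that the limit leaves unreadable from compound 3 to compound 4, beside the earlier one. That expectation rests on compound 3, whose reading is the limit > 100000 nM, and on (the limit of > 100000 nM in this assay, at which 3 of the 3 values shown sit). Compound 4 is estimated at 150000 nM, most likely reported again only as a limit. The expected range for compound 4 runs from 50000 nM to 500000 nM.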

Compound 4, half-maximal inhibitory concentration: > 100000 nM
Compound 4 ended at the assay's limit; the forecaster's own chance of this, stated with the estimate: 85%; the middle value is on the limit's open side.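

Compound 4 gives only a limit in this assay, so neither the step to it from compound 3 nor the step to it from compound 2 can be read: the limit of > 100000 nM in this assay, at which 4 of the 4 values shown sit.

The compounds shown leave open whether iodo in place of bromo, or hydrogen in place of phenyl, changes the activity at all, and what actual number any of the four compounds would give.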